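The source may report more compounds than this note shows. Statements on the series, on what has been measured and on what is new or still open speak of the compounds shown alone.

Compound 1 `CNc1nc(NCCCN(C)C)c2sc(-c3ccc(NS(C)(=O)=O)cc3)cc2n1` in a physicochemical assay for lipophilicity, read by HPLC, at pH 7.4 (on this read-out higher numbers stand for higher lipophilicity and lower numbers for lower lipophilicity), gives 2.1.
Compound 2 `CNc1nc(NCCCN(C)C)c2sc(-c3ccc(C(F)(F)F)cc3)cc2n1` in this assay gives 4.1.
Compound 3 `CNc1nc(NCCCN(C)C)c2sc(-c3ccc(C(C)=O)cc3)cc2n1` in this assay gives 2.9.

All three share one core and differ only in the group on the outer benzene ring. Compound 3 sits second highest of the three numbers, with a number 0.80 log units higher from compound 1 to compound 3 (beyond the scatter) and a number 1.20 log units lower from compound 2 to compound 3 (beyond the scatter).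

Compound 4 `CNc1nc(NCCCN(C)C)c2sc(-c3ccccc3)cc2n1` takes the next step: hydrogen in place of acetyl on an aromatic carbon. Among the compounds with values here, no measured step removes a group and leaves bare hydrogen, so the direct comparison is missing. What the measured steps do show is that swapping one group for another on this ring moves this assay by a good deal: a number 2.00 log units higher from compound 1 to compound 2 (beyond the scatter), a number 0.80 log units higher from compound 1 to compound 3 (beyond the scatter), a number 1.20 log units lower from compound 2 to compound 3 (beyond the scatter). Against that spread, taking the acetyl away is expected to shift the number upward by a modest amount, beyond the scatter but short of the largest measured step, giving an estimated a number 0.50 log units higher from compound 3 to compound 4 (beyond the scatter).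

Compound 4 is therefore estimated at 3.4 in this assay, within a range of 3 to 3.9.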

Compound 4, distribution coefficient: 2.2
For compound 4 the middle estimate is 1.20 log units above the measured one; the measured number lies below the stated range.
By their numbers in this assay, from the lowest: compounds 1 and 4 (each within the scatter of the next); then compound 3; then compound 2.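

With hydrogen on this aromatic carbon, compound 4 gives a bare-ring reference for the groups compared so far in this assay. Replacing acetyl with hydrogen lowers the number (a number 0.70 log units lower from compound 3 to compound 4 (beyond the scatter)), and replacing trifluoromethyl with hydrogen lowers it further (a number 1.90 log units lower from compound 2 to compound 4 (beyond the scatter)), whereas methanesulfonamido cannot be told apart from hydrogen (a number 0.10 log units higher from compound 1 to compound 4 (within the scatter)). Nothing given here offers a reason for these differences.

On these data alone, it remains open where an amine, a carboxylic acid or a methoxy group on this same carbon would fall relative to hydrogen in this assay. As far as these compounds go, it is also open whether these four groups would keep the same order on a core other than the one shared here.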